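Methoxyphenyl swap on the amide of compound 2

The compounds below may be only part of what the source reports. "The series", "measured", "known", "first", "only" and "open" are said of these compounds alone.

Measured in a functional assay (QGY7701 cells, Homo sapiens) for inhibition, read by MTT assay, with a stated time of 48 h; on this read-out lower numbers stand for stronger inhibition and higher numbers for weaker inhibition:
- compound 1 `COc1ccc(CNC(=O)/C=C/c2coc3cc(O)ccc3c2=O)cc1` gives 10000 nM
- compound 2 `COc1ccc2c(=O)c(/C=C/C(=O)Nc3ccccc3Cl)coc2c1` gives 23000 nM
- compound 3 `O=C(/C=C/c1coc2cc(O)ccc2c1=O)NCc1ccc(F)cc1` gives > 100000 nM as a limit

Of the two numerical values in this assay compound 2 has the higher at 23000 nM and compound 1 the lower at 10000 nM with a gap beyond the scatter. Compound 3 gives > 100000 nM and this is a limit of the assay, not a number.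

For the measured compounds named here, compound 4 `COc1ccc(NC(=O)/C=C/c2coc3cc(OC)ccc3c2=O)cc1` is not yet measured and carries 4-methoxyphenyl in place of 2-chlorophenyl on an amide-type nitrogen as its only change from compound 2.

Going by the values given here, one measured step bears on this. Fluoro in place of methoxy on an aromatic carbon gives an at least 10-fold higher number from compound 1 to compound 3 (1.00 log units; beyond the scatter) and its size rests on the limit of > 100000 nM in this assay, at which 1 of the 3 values shown sits, as well. Among the compounds with values here, that step lies on a different amide substituent from the one in compound 2, so it carries over only loosely. Within the data shown here, no measured step covers the loss of 2-chlorophenyl. A small move to a lower number is therefore expected, most likely not beyond the scatter, and the expected step is a 1.5-fold lower number from compound 2 to compound 4 (0.19 log units; within the scatter) in this estimate.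

For compound 4 the estimated value is 15000 nM with an expected range from 5000 nM to 60000 nM in this assay for now.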

Compound 4, half-maximal inhibitory concentration: > 100000 nM
Compound 4 gave a limit, no number; the forecaster's own chance of this, stated with the estimate: 12%; middle value at least 6.6-fold (0.82 log units) away from the limit.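

In this assay, the substituent on the amide-type nitrogen of compound 2 proves to be a sensitive point in the series, since 4-methoxyphenyl in place of 2-chlorophenyl gives an at least 4.3-fold higher number from compound 2 to compound 4 (0.63 log units; beyond the scatter), a step beyond the scatter in the direction of weaker inhibition. For the compounds shown here, compound 4 gives > 100000 nM, which is a limit and not a number, so the step fixes only a minimum size and the true gap stays unknown: the limit of > 100000 nM in this assay, at which 2 of the 4 values shown sit. The step from compound 1 to compound 3 had the methoxy-bearing compound as the one with a number, whereas here the 4-methoxyphenyl compound is the one at the limit, so a methoxy group on the amide substituent does not by itself go with a measurable value across the series.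

The compounds shown do not separate the loss of the chlorine from the entry of the methoxy group, as both changes arrive together in this single step. On these data alone, whether plain phenyl, or a ring carrying an amine or a carboxylic acid, on this nitrogen would keep a number in this read-out remains open.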